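The compounds below may be only part of what the source reports. "The series", "measured", "known", "first", "only" and "open" are said of these compounds alone.

Of the compounds shown here, three have so far been tested in a functional assay on IMR-32 cells (Homo sapiens) for cytotoxicity, read by sulforhodamine B assay, with a stated time of 48 h; on this read-out higher numbers stand for weaker inhibition and lower numbers for stronger inhibition. Compound 1 `CC(=O)N1N=C(c2ccccc2)CC1c1ccc(N(C)C)cc1` gives 9660 nM in this assay. Compound 2 `CC(=O)N1N=C(c2ccco2)CC1c1cccc(O)c1` gives 11800 nM. Compound 3 `CC(=O)N1N=C(c2ccco2)CC1c1ccc(Br)cc1` gives 47800 nM, the highest of the three numbers and so the weakest inhibitor of the set: compound 2 stands nearest to it and compound 1 furthest, and both gaps lie beyond the usual scatter of repeated measurements.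

Compound 4 `CC(=O)N1N=C(c2ccco2)CC1c1ccc(N(C)C)cc1` has not yet been measured. It differs from compound 3 in a single place: dimethylamino in place of bromo on an aromatic carbon. Going by the values given here, no two measured compounds differ in just this one position, so no measured step shows directly what this exchange does. The same dimethylamino group is carried by compound 1, which otherwise differs from compound 4 elsewhere; compound 1 gives 9660 nM, well below the number of compound 3. On that ground a move toward lower numbers is expected, large enough to stand beyond the scatter, and the expected step is a 4.0-fold lower number from compound 3 to compound 4 (0.60 log units; beyond the scatter). Compound 4 is accordingly estimated at 12000 nM, with a range from 4000 nM to 36000 nM.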

Compound 4, half-maximal inhibitory concentration: 16100 nM
Estimate against measurement, compound 4: 1.3-fold (0.13 log units) below, within the range that was stated.
By their numbers in this assay, from the lowest: compounds 1, 2 and 4 (each within the scatter of the next); then compound 3.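

In this assay, going by these compounds alone, dimethylamino in place of bromo on the aromatic carbon para to a large group gives a 3.0-fold lower number from compound 3 to compound 4 (0.47 log units; beyond the scatter) on a shared furan-2-yl background, the first direct reading of an exchange at this position, and it shows that the number responds to the group carried there. Within the data shown here, with dimethylamino held in place, furan-2-yl in place of phenyl on the carbon with a double bond to nitrogen gives a 1.7-fold higher number from compound 1 to compound 4 (0.22 log units; within the scatter) and stays within the scatter, so in this assay this pair cannot be told apart, a comparison the earlier compounds could not offer. No measurement shown here gives a reason for either step.

The compounds shown leave open whether a primary amine, a methoxy group or a carboxylic acid on the same aromatic carbon would read closer to dimethylamino or to bromo, since only these two groups can be compared there. They also leave open whether the exchange of bromo for dimethylamino gives a step of similar size when phenyl takes the place of furan-2-yl.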